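The compounds below may be only part of what the source reports. "The series", "measured", "known", "first", "only" and "open" are said of these compounds alone.

Measured compounds:
- compound 1, `COc1ccc(/C=C/c2ccc(OCCCC(C)(C)C(=O)O)cc2)cc1`: 1.65 ug/mL
- compound 2, `CC(C)(Oc1ccc(CCCOc2ccc(/C=C/c3ccccc3)cc2)cc1)C(=O)O`: 27 ug/mL

In a physicochemical assay for solubility, read by spectrophotometry, measured as thermodynamic solubility, with a stated time of 24 h, at pH 7.4 (on this read-out lower numbers stand for lower solubility and higher numbers for higher solubility), compound 2 gives 27 ug/mL, the higher of the two numbers; compound 1 gives 1.65 ug/mL, and the gap between them lies well beyond the scatter. Compound 3, `CC(C)(Oc1ccc(CCCOc2ccc(C(=O)/C=C/c3ccccc3)cc2)cc1)C(=O)O`, has not yet been measured. It differs from compound 2 in one place: (2-phenylethenyl)carbonyl in place of 2-phenylethenyl on an aromatic carbon. For the measured compounds named here, no measured pair shows this change, so its effect can only be estimated. The step from compound 2 to compound 3 in this assay is expected to be small, a 1.1-fold higher number from compound 2 to compound 3 (0.05 log units; within the scatter), not beyond the scatter in either direction. Compound 3 is therefore expected to give about 30 ug/mL, within a range from 10 ug/mL to 80 ug/mL.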

Compound 3, solubility: 17.5 ug/mL
Beside the measured number, compound 3's estimate is 1.7-fold (0.23 log units) above it, within the range that was stated.
By their numbers in this assay, from the lowest: compound 1; then compounds 3 and 2 (each within the scatter of the next).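

Within this assay the change from 2-phenylethenyl to (2-phenylethenyl)carbonyl, on an aromatic carbon para to a large group, gives the first reading of this position (a 1.5-fold lower number from compound 2 to compound 3 (0.19 log units; within the scatter)). For the compounds shown here, at this position, then, the added carbonyl leaves the number within the scatter of compound 2, which no earlier pair could show. Nothing available explains this result.

Still open, going by these compounds, is whether an amine or a longer chain at this position would give a step beyond the scatter. On these data alone, whether the carbonyl would give a similar step on the core of compound 1 also remains open.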